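This account rests on a few compounds, and the source may have more. Where it says the series, first, only, none or still open, it means among the compounds named here.

For the measured compounds named here, only three measurements frame this step, so any forecast has to stay loose. In a functional assay on PC-3 cells (Homo sapiens) for antiproliferative activity, read by WST assay, with a stated time of 72 h (on this read-out lower numbers stand for stronger inhibition of growth and higher numbers for weaker inhibition of growth), compound 1 (`C#Cc1cccc(N/N=N/c2ccc(C(=N)N)cc2)c1`) gives 18000 nM and stands level with its nearest neighbour. That neighbour is compound 3 (`C#Cc1ccc(N/N=N/c2ccc(C(=N)N)cc2)cc1`), which gives 22500 nM and lies within the usual scatter of compound 1, so the two cannot be ranked. Compound 2 (`C#Cc1ccccc1N/N=N/c1ccc(C(=N)N)cc1`) is recorded as > 50000 nM in this assay and this is a limit of the assay, not a number.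

The step to follow leads to compound 4 (`N=C(N)c1ccc(/N=N/Nc2cccc(C#Cc3ccccc3)c2)cc1`). It has phenyl in place of hydrogen on a triple-bonded carbon, so that ethynyl becomes 2-phenylethynyl (phenyl in place of hydrogen on a triple-bonded carbon). Going by the values given here, no measured pair of compounds shows what this change does, which leaves the direction uncertain. A moderate move towards lower numbers, meaning stronger inhibition of growth, is the expectation, since compound 1 at 18000 nM leaves ample room for a gain. A result within the scatter of compound 1 would still be unsurprising. The estimated change is (a 2.0-fold lower number from compound 1 to compound 4 (0.30 log units; within the scatter)) and it is only a rough expectation. For compound 4 the expected value is 9000 nM with an estimated range of 2500 nM to (30000 nM).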

Compound 4, concentration for 50% growth inhibition: 5800 nM
For compound 4 the middle estimate is 1.6-fold (0.19 log units) above the measured one, within the range that was stated.
By their numbers in this assay, from the lowest: compound 4; then compounds 1 and 3 (each within the scatter of the next). At a limit, above all of these: compound 2.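

Until this step, every compound carried a plain ethynyl with hydrogen on its triple-bonded carbon, so nothing showed whether that carbon could hold anything larger. In this assay the change from ethynyl to 2-phenylethynyl, which adds one six-membered aromatic ring of carbon only, gives a 3.1-fold lower number from compound 1 to compound 4 (0.49 log units; beyond the scatter) and so shows, for this one pair, that the ring is not only accepted at this carbon but goes with stronger inhibition of growth, although the step is modest. Nothing in the data at hand bears on why the number falls with this change.

On these data alone, a single pair gives one example and no trend, so it remains open whether an aromatic ring is what matters here, or whether a pyridine ring, a butyl chain or a hydroxymethyl group on the same triple-bonded carbon would shift the number in the same direction. As far as these compounds go, it is equally open whether the same change, made on compound 3, would give a step of similar size.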